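The compounds below may be only part of what the source reports. "The series", "measured", "known", "first", "only" and "open" are said of these compounds alone.

Within the data shown here, compound 2, with structure `O=C(Nc1cccc(OCc2cn(-c3ccc(Br)cc3)nn2)c1)Nc1ccc(Cl)c(C(F)(F)F)c1`, is one of two compounds measured in a functional assay on HepG2 cells (Homo sapiens) for inhibition, read by MTT assay, with a stated time of 72 h (a higher number here means a weaker inhibitor, a lower number a stronger inhibitor), where compound 2 gives 2730 nM. Compound 1, with structure `CC(C)c1ccc(-n2cc(COc3cccc(NC(=O)Nc4ccc(Cl)c(C(F)(F)F)c4)c3)nn2)cc1`, gives 2470 nM in this assay. Compound 2 therefore has the higher of the two numbers, but the two stand within the scatter of each other, and the step of a 1.1-fold higher number from compound 1 to compound 2 (0.04 log units; within the scatter) reflects no more than that.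

Compound 3, with structure `O=C(Nc1cccc(OCc2cn(-c3ccc(I)cc3)nn2)c1)Nc1ccc(Cl)c(C(F)(F)F)c1`, is not yet measured. It differs from compound 2 in one place: iodo in place of bromo on an aromatic carbon. Among the measured compounds shown here, only one measured step is available for comparison, the change from compound 1 to compound 2, in which a bromo replaced an isopropyl at the same aromatic carbon, and that step a 1.1-fold higher number from compound 1 to compound 2 (0.04 log units; within the scatter) stayed within the scatter. That change is not the same as the present one, so it bears on it only loosely; a single exchange of one heavy atom for another at this position has, so far, left the number essentially unchanged.

Compound 3 is accordingly expected to show a 1.0-fold lower number from compound 2 to compound 3 (0.00 log units; within the scatter), nothing beyond the scatter, and compound 3 is estimated at 2700 nM, with a range from 1300 nM to 5600 nM.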

Compound 3, half-maximal inhibitory concentration: 2690 nM
Compound 3: middle estimate off by 1.0-fold (0.00 log units), on the high side; low and high end bracket the measured number.
By their numbers in this assay, from the lowest: compounds 1, 3 and 2 (each within the scatter of the next).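

In this assay, the exchange of one halogen for another at this carbon gives a 1.0-fold lower number from compound 2 to compound 3 (0.01 log units; within the scatter) and the exchange of isopropyl for iodo gives a 1.1-fold higher number from compound 1 to compound 3 (0.04 log units; within the scatter), so both steps lie within the scatter. Where the earlier pair offered only isopropyl against bromo, the position para to a large group now carries three different substituents, isopropyl, bromo and iodo, and the number does not separate any of them, with none of the three compounds going against this. No measurement given here offers a reason for this result.

From the compounds shown here alone, what remains open is whether a group of another kind on this aromatic carbon, such as an amine, a carboxylic acid or a longer chain, would take the number beyond the scatter, since the three groups compared here give no sign of where such a limit might lie. Also open, going by these compounds, is whether the same lack of separation would hold for these groups at another carbon of the ring, or for the same changes made on a different core.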